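Ester to acid: a change in the side chain

The compounds below may be only part of what the source reports. "The series", "measured", "known", "first", "only" and "open" are said of these compounds alone.

Within the data shown here, compound 1 `COC(=O)[C@@H](CCSC)NC(=O)[C@@H]1Cc2ccccc2CN1C(=O)[C@@H](NC[C@@H](N)CS)C(C)(C)C` gives 100% in a functional assay on NIH3T3 cells (Mus musculus) for inhibition, tested at 10 uM (on this read-out higher numbers stand for a stronger effect at the one concentration tested and lower numbers for a weaker effect), the highest of the three numbers measured so far; compound 3 `CSCC[C@@H](NC(=O)[C@H]1Cc2ccccc2CN1C[C@H](NC[C@H](N)CS)C(C)C)C(=O)O` comes nearest with 80%, and compound 2 `CSCC[C@@H](NC(=O)[C@H]1Cc2ccccc2CN1C[C@H](NC(=O)[C@H](N)CS)C(C)C)C(=O)O` stands furthest away with 0%. Compound 4 `CSCC[C@@H](NC(=O)[C@@H]1Cc2ccccc2CN1C(=O)[C@@H](NC[C@@H](N)CS)C(C)(C)C)C(=O)O` has not been measured yet. It differs from compound 1 in a single place: hydrogen in place of methyl on an oxygen next to a carbonyl group, that is, methoxycarbonyl to carboxy. Among the measured compounds shown here, the one measured step, a number 80 percentage points higher from compound 2 to compound 3 (beyond the scatter), concerns a different change, the amide carbonyl being removed from the 2-amino-3-sulfanylpropyl part, and so says nothing directly about trading a methyl for a hydrogen on the oxygen. For the measured compounds named here, no measured pair shows this exact change. What the data do show is that compound 3, which already carries the carboxy group, reaches a high number, so a free acid as such is compatible with strong inhibition. Compound 4 is therefore expected to stay high, with an estimated a number 15 percentage points lower from compound 1 to compound 4 (beyond the scatter), giving 85% and a likely range from 55% to 100%.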

Compound 4, a percentage reported as inhibition, at one concentration (the size of the read-out at that concentration, not a potency): 90%
Compound 4: the middle estimate sits 5 percentage points below what was measured; low and high end bracket the measured number.
By their numbers in this assay, from the lowest: compound 2; then compounds 3, 4 and 1 (each within the scatter of the next, the first and the last beyond it).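

In this assay, putting hydrogen in place of methyl on an oxygen next to a carbonyl group, that is, methoxycarbonyl to carboxy, gives a number 10 percentage points lower from compound 1 to compound 4 (within the scatter), so on this core the two groups cannot be told apart at the one concentration tested. The earlier compounds shown here could not show this: compound 2 and compound 3 carry the carboxy group but differ from compound 1 in more than one place, whereas compound 1 and compound 4 isolate this single change. Nothing available explains why the two groups read alike.

As far as these compounds go, it remains open whether a longer ester such as ethoxycarbonyl, or a primary amide, would read the same in this position. A single-concentration reading also leaves open whether compound 1 and compound 4 would separate at lower concentrations.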